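Notes on cytotoxicity limits across the series

A few compounds are considered here, and "the series" means these few. Any claim that something is new, unique, unknown or untested is made for them only; others in the source may bear on it.

Compound 1 `COC(=O)c1ccc(NCc2cncn2Cc2cccc(Br)c2)cc1-c1ccccc1`, compound 2 `COC(=O)c1ccc(NCc2cncn2Cc2cccc([N+](=O)[O-])c2)cc1-c1ccccc1` and compound 3 `c1ccc(-c2ccc(Cn3cncc3CNc3ccc(-c4ccccc4)c(-c4ccccc4)c3)cc2)cc1` share one core and have each been tested in a toxicity assay on NIH3T3 cells (Mus musculus) for cytotoxicity, read by resazurin assay; a higher number here means that more compound is needed for the effect, a lower number that less compound is needed. In this assay compound 1 reaches only the limit > 10000 nM. Compound 2 likewise gives only the limit > 10000 nM. Compound 3 also stops at the limit > 10000 nM, so it stands level with the other two and no ordering among them can be read. Going by the values given here, the single one-point step that the two limits leave unreadable from compound 1 to compound 2 is unreadable because the limit of > 10000 nM in this assay, at which 3 of the 3 values shown sit, holds both of its ends. Compound 4 `CCOC(=O)c1ccc(NCc2cncn2Cc2ccc(-c3ccccc3)cc2)cc1-c1ccccc1` has not yet been measured. It differs from compound 3 by ethoxycarbonyl in place of phenyl on an aromatic carbon. Among the compounds with values here, no measured step covers this change, and none of the three measured values gives a number to move from. The expected outcome for compound 4 is therefore that this assay again reports a limit rather than a number, an expected step that the limit leaves unreadable from compound 3 to compound 4. The estimate for compound 4 is 15000 nM, within 8000 nM to 40000 nM.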

Compound 4, half-maximal effective concentration: > 10000 nM
Compound 4: a limit, no number; the forecaster's own chance of this, stated with the estimate: 80%; the middle value does not contradict the limit.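

No step can be read from compound 3 to compound 4, because both stop at a limit and not a number: the limit of > 10000 nM in this assay, at which 4 of the 4 values shown sit.

The compounds shown leave open at what concentration any of them becomes cytotoxic, and whether ethoxycarbonyl in place of phenyl shifts that concentration at all.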